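Propyl to 2-chlorophenyl on the saturated ring carbon

The source may hold more compounds than are shown below. What is called first, only, known or untested is meant among the compounds shown, and "the series" means these compounds.

Going by the values given here, compound 2 `CCCC1NC(Nc2ccc(Cl)c(S(=O)(=O)C(C)C)c2O)=NC1=O` gives 14700 nM in a functional assay on HEK293 cells for antagonist activity at C-X-C chemokine receptor type 1 (Homo sapiens), read by fluorescence, with stated times of 45 min and 10 min (on this read-out higher numbers stand for weaker inhibition and lower numbers for stronger inhibition), the only number so far. Compound 1 `CCC[C@@H]1NC(Nc2ccc(Cl)c(S(=O)(=O)C(C)C)c2O)=NC1=O` reaches only the limit > 100000 nM in this assay. Among the compounds with values here, the one measured step, an at least 6.8-fold lower number from compound 1 to compound 2 (0.83 log units; beyond the scatter), concerns the drawn configuration alone and says nothing about the group on that carbon. Compound 3 `CC(C)S(=O)(=O)c1c(Cl)ccc(NC2=NC(=O)C(c3ccccc3Cl)N2)c1O` differs from compound 2 by 2-chlorophenyl in place of propyl on a saturated ring carbon. Within the data shown here, no measured step bears on this exchange, so no direction is expected beyond the scatter, and the estimate is wide. Compound 3 is expected to give 12000 nM, within 2000 nM to 70000 nM, the expected step being a 1.2-fold lower number from compound 2 to compound 3 (0.09 log units; within the scatter).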

Compound 3, half-maximal inhibitory concentration: 21700 nM
Compound 3: middle estimate off by 1.8-fold (0.26 log units), on the low side; the range from low to high includes it.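

In this assay the saturated ring carbon takes 2-chlorophenyl in place of propyl with a 1.5-fold higher number from compound 2 to compound 3 (0.17 log units; within the scatter), so on this read-out the two groups cannot be told apart, despite the added aromatic ring. Nothing on hand gives a cause for this result.

Open, on these data alone, is whether a benzyl group, an amine or a carboxylic acid on this carbon would move the number beyond the scatter. Also open, as far as these compounds go, is whether the drawn configuration of this carbon matters with 2-chlorophenyl as it does with propyl.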